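The source may hold more compounds than are shown below. What is called first, only, known or untested is meant among the compounds shown, and "the series" means these compounds.

Compound 1 `CC(C)(C)OC(=O)N1CCC2(CCN(c3cncc4ccccc34)CC2)C1` belongs to the same series. In an ADME assay on V79 cells for inhibition of cytochrome P450 11B1, mitochondrial (Homo sapiens), read by HTRF, with stated times of 1 h and 3 h (a higher number here means a weaker inhibitor, a lower number a stronger inhibitor), compound 1 returns only a limit, > 8000 nM. For the measured compounds named here, compound 2 `CN1CC2(CCN(c3cncc([C@](C)(O)C(F)(F)F)c3)CC2)CC1=O` gives the only number in this assay, 1540 nM. The other value shown, that of compound 1, is a limit: the limit of > 8000 nM in this assay, at which 1 of the 2 values shown sits. Compound 3 `CN1CC2(CCN(c3cncc([C@@](C)(O)C(F)(F)F)c3)CC2)CC1=O` differs from compound 2 only in configuration: the two compounds have the same atoms and bonds and differ only in configuration as drawn: 1 of 1 stereo elements differ; a stereocentre at a saturated chain carbon is drawn S in compound 2 and R in compound 3. Going by the values given here, no measured pair shows such a step, so the direction is open; the two mirror forms may well differ beyond the scatter. The estimate for compound 3 in this assay is 2500 nM, between 400 nM and 15000 nM, an expected step of a 1.6-fold higher number from compound 2 to compound 3 (0.21 log units; within the scatter).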

Compound 3, half-maximal inhibitory concentration: 10000 nM
Compound 3: middle estimate off by 4.0-fold (0.60 log units), on the low side; the measured number falls inside the stated range.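

The stereocentre at the saturated chain carbon counts in this assay: drawn R rather than S, it gives the weaker inhibitor, with a 6.5-fold higher number from compound 2 to compound 3 (0.81 log units; beyond the scatter). The earlier compounds shown here offered no pair that could isolate this centre, and here the step can rest on configuration alone: the fact that compounds 2 and 3 differ only in the configuration as drawn. This is a single pair, so it speaks for this one stereocentre on this one scaffold. As far as these compounds go, whether a similar gap between the two forms would remain with a methoxy group in place of the hydroxyl on that carbon stays open.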